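Swapping the methoxy for cyano on a quinazoline-type antagonist

The source may hold more compounds than are shown below. What is called first, only, known or untested is meant among the compounds shown, and "the series" means these compounds.

Of the compounds shown here, two have been measured in a functional assay on HEK293 cells for antagonist activity at metabotropic glutamate receptor 5 (Rattus norvegicus), read by calcium flux; on this read-out lower numbers stand for stronger inhibition and higher numbers for weaker inhibition. Compound 1 `Fc1ccc2ncnc(Nc3cccc(Cl)c3)c2c1` gives 311 nM. Compound 2 `COc1ccc2ncnc(Nc3cccc(Cl)c3)c2c1` gives 1510 nM, the highest of the two numbers, so compound 2 is the weaker inhibitor of the pair. Among the compounds with values here, the only change between them, a 4.9-fold higher number from compound 1 to compound 2 (0.69 log units; beyond the scatter), is a modest step beyond the usual scatter.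

The next compound, compound 3 `N#Cc1ccc2ncnc(Nc3cccc(Cl)c3)c2c1`, again keeps the whole shared core and changes one group on it: cyano in place of methoxy on an aromatic carbon. Within the data shown here, no measured step shows what cyano does at this place, so the expectation rests only on the one measured step, which concerns the methoxy group that now leaves. From the compounds shown here alone, because introducing methoxy produced a 4.9-fold higher number from compound 1 to compound 2 (0.69 log units; beyond the scatter), removing it in favour of another small group is expected to move the number back down, toward the level of compound 1, though by how much remains open. Compound 3 is therefore expected to give 350 nM in this assay, within a range of 100 nM to 1200 nM, which means an expected step of a 4.3-fold lower number from compound 2 to compound 3 (0.63 log units; beyond the scatter).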

Compound 3, half-maximal inhibitory concentration: > 10000 nM
Compound 3: only a limit was reported; the forecaster's own chance of this, stated with the estimate: 2%; at least 28-fold (1.45 log units) between middle value and limit.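

The value for compound 3 is a limit of the assay and not a number: the limit of > 10000 nM in this assay, at which 1 of the 3 values shown sits. Even so, this place on the aromatic ring proves much less forgiving than the first pair suggested: cyano in place of methoxy gives an at least 6.6-fold higher number from compound 2 to compound 3 (0.82 log units; beyond the scatter), and cyano in place of fluoro gives an at least 32-fold higher number from compound 1 to compound 3 (1.50 log units; beyond the scatter), the second a large step. Methoxy and cyano have the same count of heavy atoms and of hydrogen-bond acceptors, and neither carries a net charge, so these counts alone do not decide how a group fares at this place, and the earlier pair could not have shown that.

How far compound 3 lies past the limit stays unknown, so the true size of both steps remains open, and nothing shown explains why cyano behaves so differently from fluoro and methoxy here. From the compounds shown here alone, it is also open whether the loss is particular to cyano or would also appear with other groups at this place, such as a methyl group, an amine or a carboxylic acid.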